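The compounds below may be only part of what the source reports. "The series", "measured", "known", "first", "only" and "open" are said of these compounds alone.

Compound 1, `O=c1cc(/C=N\c2ccccc2O)c2c(OCc3ccccc3)cc(OCc3ccccc3)cc2o1`, gives the lowest of the two numbers recorded in a functional assay, read by spectrophotometry, with a stated time of 1 h (a higher number here means a weaker inhibitor, a lower number a stronger inhibitor), at 348000 nM. Compound 3, `O=c1cc(/C=N\Nc2ccc([N+](=O)[O-])cc2[N+](=O)[O-])c2c(OCc3ccccc3)cc(OCc3ccccc3)cc2o1`, gives 734000 nM in this assay. Compound 2, `N/N=C\c1cc(=O)oc2cc(OCc3ccccc3)cc(OCc3ccccc3)c12`, gives only > 2000000 nM in this assay, which is a limit rather than a number (the limit of > 2000000 nM in this assay, at which 1 of the 3 values shown sits). The two measured steps are an at least 5.7-fold higher number from compound 1 to compound 2 (0.75 log units; beyond the scatter) and an at least 2.7-fold lower number from compound 2 to compound 3 (0.43 log units; beyond the scatter); both alter the group on the double-bonded nitrogen, and neither touches a benzyloxy group. Compound 4, `O=c1cc(/C=N\c2ccccc2O)c2ccc(OCc3ccccc3)cc2o1`, differs from compound 1 in another place: hydrogen in place of benzyloxy on an aromatic carbon. Within the data shown here, no measured step bears on this change, so compound 4 is expected to stay close to compound 1, with a 1.4-fold higher number from compound 1 to compound 4 (0.16 log units; within the scatter). The estimate for compound 4 in this assay is 500000 nM, within 150000 nM to 1800000 nM.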

Compound 4, half-maximal inhibitory concentration: "not active" (no number reported)
For compound 4 the study gives words and no number, so the estimate cannot be set against anything.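

In this assay compound 4 is reported in words without a number, so no step from compound 1 to compound 4 can be read, and nothing shown bears on this result. The compounds shown leave open how far hydrogen in place of benzyloxy shifts the number.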